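This account rests on a few compounds, and the source may have more. Where it says the series, first, only, none or still open, it means among the compounds named here.

In a physicochemical assay for lipophilicity, in phosphate buffer, measured as octanol-water partition (a lower number here means a more polar compound, a higher number a more lipophilic compound), compound 2 `O=c1c2ccccc2nc(-c2ccccc2)n1/N=C/c1ccc(Oc2ccc([N+](=O)[O-])cc2)cc1` gives 6.12, the highest of the three numbers obtained so far. The nearest is compound 1 `Cc1nc2ccccc2c(=O)n1/N=C/c1ccc(Oc2ccc([N+](=O)[O-])cc2)cc1`, which gives 4.01 in this assay, and the furthest is compound 3 `Cc1nc2ccccc2c(=O)n1/N=C1/C(=O)Nc2ccccc21`, which gives 2.23; both gaps lie beyond the scatter. Among the measured compounds shown here, the one step between measured compounds that differ in a single place is a number 2.11 log units higher from compound 1 to compound 2 (beyond the scatter), a large move within this assay.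

Compound 4 `O=c1c2ccccc2nc(-c2ccccc2)n1/N=C/c1ccc(Oc2ccc(Cl)cc2)cc1` has not yet been measured. It differs from compound 2 by chloro in place of nitro on an aromatic carbon. For the measured compounds named here, no measured pair shows this exchange, and the step from compound 1 to compound 2 concerns another group entirely, so it offers no direct guide to the size of this one. Going by the values given here, the data therefore give no measured precedent, and the expectation rests on the nature of the exchange alone. An increase beyond the scatter is expected, amounting to a number 0.68 log units higher from compound 2 to compound 4 (beyond the scatter). Compound 4 is accordingly estimated at 6.8 in this assay, with a range from 6.2 to 7.4.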

Compound 4, partition coefficient: 6.38
Estimate against measurement, compound 4: 0.42 log units above; low and high end bracket the measured number.
By their numbers in this assay, from the lowest: compound 3; then compound 1; then compounds 2 and 4 (each within the scatter of the next).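

In this assay, chloro in place of nitro on the aromatic carbon para to a large group gives a number 0.26 log units higher from compound 2 to compound 4 (within the scatter), so the two compounds cannot be told apart at this position. Among the compounds shown here, this is the first exchange read at this place, since the earlier step concerned a different part of the molecule, and here a group of 3 heavy atoms and 2 hydrogen-bond acceptors gives way to one of 1 heavy atom and 0 acceptors without a difference beyond the scatter. No measurement shown accounts for this result.

On these data alone, it remains open whether an amine or a carboxylic acid at this position would also stay within the scatter of compound 2. As far as these compounds go, it is equally open whether 4-nitrophenoxy and 4-chlorophenoxy would read alike with methyl on the core, as in compound 1.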